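This account rests on a few compounds, and the source may have more. Where it says the series, first, only, none or still open, it means among the compounds named here.

Measured in a functional assay on MCF7 cells (Homo sapiens) for inhibition, read by MTT assay, with a stated time of 48 h; a lower number here means a stronger inhibitor, a higher number a weaker inhibitor:
Compound 1, `COc1ccc(CN(c2cc(OC)c(OC)c(OC)c2)S(=O)(=O)c2ccc(C(C)(C)C)cc2)cc1`: 32700 nM
Compound 2, `Cc1ccc(S(=O)(=O)N(Cc2nc3ccccc3[nH]2)c2ccc(Cl)cc2)cc1`: 38300 nM

Compound 2 and compound 1 lie within the usual scatter of each other in this assay, so neither stands apart from the other; both are weak inhibitors on the scale shown. Compound 3, `Cc1ccc(N(Cc2nc3ccccc3[nH]2)S(=O)(=O)c2ccc(C)cc2)cc1`, has not yet been measured. It differs from compound 2 in one place: methyl in place of chloro on an aromatic carbon. Going by the values given here, no step between two measured compounds shows what this exchange does to the number in this assay; compound 1 and compound 2 differ in several places at once and say nothing about it. The expectation therefore rests on the size of the change alone, one heavy atom for one heavy atom, with no donor, acceptor or ring gained or lost. Compound 3 is expected to stay close to compound 2, with an estimated step of a 1.1-fold higher number from compound 2 to compound 3 (0.04 log units; within the scatter) that need not go beyond the scatter in either direction. The estimate for compound 3 in this assay is 42000 nM, with a range from 15000 nM to 120000 nM.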

Compound 3, half-maximal inhibitory concentration: > 50000 nM
Compound 3: no number, only a limit (the forecaster's own chance of this, stated with the estimate: 25%); middle value at least 1.1-fold (0.07 log units) from the limit.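

In this assay compound 3 gives > 50000 nM as its reading, which is a limit of the assay and not a number. The exchange of chloro for methyl on this aromatic carbon, para to a large group, can now be read for the first time, and the change from 4-chlorophenyl to 4-methylphenyl gives an at least 1.3-fold higher number from compound 2 to compound 3 (0.11 log units; that floor lies within the scatter) as its step, so the exchange is not shown to move the number beyond the scatter, though a larger step is not excluded. The step has only a floor and no size because compound 3 sits at the limit of the scale: the limit of > 50000 nM in this assay, at which 1 of the 3 values shown sits.

What the compounds shown leave open is how other groups at this place would read, such as an amine, a carboxylic acid or a longer chain, since chloro and methyl are the only two groups compared here. Going by these compounds, it also remains open whether the same exchange would give a step of measurable size on a compound with a lower number, one whose reading sits clear of the limit.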